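A few compounds are considered here, and "the series" means these few. Any claim that something is new, unique, unknown or untested is made for them only; others in the source may bear on it.

Measured so far in a functional assay on SiHa cells (Homo sapiens) for cytotoxicity, read by MTT assay, with a stated time of 48 h; a higher number here means a weaker inhibitor, a lower number a stronger inhibitor:
compound 1, `CCCCCCCCNC(=O)[C@@H](NC(=O)/C=C/c1ccccc1)[C@@H](C)O`, gives 41400 nM;
compound 2, `C/C=C/C=C/C(=O)N[C@H](C(=O)NCCCCCCCC)[C@@H](C)O`, gives 123000 nM;
compound 3, `CCCCCCCCCCCCCCCCCCNC(=O)[C@@H](NC(=O)/C=C/c1ccccc1)[C@@H](C)O`, gives 35900 nM.

Compound 4, `C/C=C/C=C/C(=O)N[C@H](C(=O)NCCCCCCCCCCCCCCCCCC)[C@@H](C)O`, is not yet measured. Compound 1 and compound 3 lie within the scatter of each other, while compound 2 stands apart from both. The change from compound 1 to compound 2 is prop-1-en-1-yl in place of phenyl on a double-bonded chain carbon bound to a double-bonded chain carbon; it made a 3.0-fold higher number from compound 1 to compound 2 (0.47 log units; beyond the scatter). The cores of compound 1 and compound 3 differ by decyl in place of hydrogen on a saturated chain carbon, eight bonds along the chain from an amide-type nitrogen, which made a 1.2-fold lower number from compound 1 to compound 3 (0.06 log units; within the scatter). Compound 4 differs from compound 3 by prop-1-en-1-yl in place of phenyl on a double-bonded chain carbon bound to a double-bonded chain carbon, the same change at the same place. Because the same change on compound 1 made a 3.0-fold higher number from compound 1 to compound 2 (0.47 log units; beyond the scatter), and because the cores differ only by a 1.2-fold lower number from compound 1 to compound 3 (0.06 log units; within the scatter), a comparable step is expected for compound 4: a 3.0-fold higher number from compound 3 to compound 4 (0.48 log units; beyond the scatter). Compound 4 is therefore estimated at 108000 nM, expected between 55000 nM and 220000 nM.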

Compound 4, half-maximal inhibitory concentration: > 200000 nM
Compound 4 ended at the assay's limit; the forecaster's own chance of this, stated with the estimate: 10%; at least 1.8-fold (0.26 log units) between middle value and limit.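

In this assay compound 4 gives > 200000 nM, which is a limit of the assay and not a number. Prop-1-en-1-yl in place of phenyl gives a higher number on both cores, with an at least 5.5-fold higher number from compound 3 to compound 4 (0.74 log units; beyond the scatter), so the direction carries over between these two cores, but whether the size of the step carries over is not shown: the same change on two cores in this assay, a 3.0-fold higher number (0.47 log units; beyond the scatter) from compound 1 to compound 2 and an at least 5.5-fold higher number (0.74 log units; beyond the scatter) from compound 3 to compound 4; the limit leaves it open whether they differ The decyl change, now with an at least 1.6-fold higher number from compound 2 to compound 4 (0.21 log units; that floor lies within the scatter), likewise gives no sign of whether the chain matters differently on the two cores: the same change on two cores in this assay, a 1.2-fold lower number (0.06 log units; within the scatter) from compound 1 to compound 3 and an at least 1.6-fold higher number (0.21 log units; that floor lies within the scatter) from compound 2 to compound 4; the limit leaves it open whether they differ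

The compounds shown leave open how a carboxylic acid or an amine in place of phenyl would read in this assay. They also leave open whether the phenyl change carries over to a core with a longer chain.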